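The source may report more compounds than this note shows. Statements on the series, on what has been measured and on what is new or still open speak of the compounds shown alone.

Working notes on the series. Of the compounds shown here, three have been measured in an ADME assay on isolated protein for inhibition of Amine oxidase [flavin-containing] B (Homo sapiens); on this read-out higher numbers stand for weaker inhibition and lower numbers for stronger inhibition. Compound 3 `C#CCNC1CCc2c(SCc3cccc(OC)c3)cccc21` gives 1520 nM. Within the data shown here, compound 1 `C#CCNC1CCc2c(SCc3cccc(C(F)(F)F)c3)cccc21` gives 7710 nM, and the step of a 5.1-fold higher number from compound 3 to compound 1 (0.71 log units; beyond the scatter) is the only single-point change with two measured ends; it is described as trifluoromethyl in place of methoxy on an aromatic carbon. Compound 2 `C#CCNC1CCc2c(SCCc3ccc(OC)cc3)cccc21` carries a different core and gives 4590 nM in this assay; its number lies within the scatter of that of compound 1 and is higher than that of compound 3. The difference between the core of compound 2 and the core of compound 3 is not broken down here.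

Compound 4 `C#CCNC1CCc2c(SCCc3ccc(C(F)(F)F)cc3)cccc21` is not yet measured. It differs from compound 2 as trifluoromethyl in place of methoxy on an aromatic carbon. Among the measured compounds shown here, this is the same kind of change as the one from compound 3 to compound 1, not the same change: in compound 1 the entering group sits meta to a large group, in compound 4 it sits para to a large group, and the two cores differ. For the measured compounds named here, only one measured precedent exists, so its transfer to the other core and position is uncertain. Compound 4 is expected to show a step of a 2.8-fold higher number from compound 2 to compound 4 (0.45 log units; beyond the scatter), somewhat smaller than the step of a 5.1-fold higher number from compound 3 to compound 1 (0.71 log units; beyond the scatter) on which it rests, the discount reflecting the change of core and position. Compound 4 is therefore estimated at about 13000 nM in this assay, most likely between 4500 nM and 40000 nM.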

Compound 4, half-maximal inhibitory concentration: 8780 nM
Beside the measured number, compound 4's estimate is 1.5-fold (0.17 log units) above it; low and high end bracket the measured number.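

On the core of compound 2, trifluoromethyl in place of methoxy on an aromatic carbon gives a 1.9-fold higher number from compound 2 to compound 4 (0.28 log units; within the scatter) in this assay, so on this core alone the change cannot be told apart from repeat-measurement noise. Set beside the earlier step on the other core, the two steps do not differ by more than two such steps can differ by chance, so the data are compatible with the change carrying over from one core to the other: the same change on two cores in this assay, a 5.1-fold higher number (0.71 log units; beyond the scatter) from compound 3 to compound 1 and a 1.9-fold higher number (0.28 log units; within the scatter) from compound 2 to compound 4, 2.7-fold (0.42 log units) apart, within the scatter of two such steps Two pairs do not establish a constant step size for this change, however, and they cannot separate any influence of the core from that of where the group sits on the aromatic ring, since both differ between the pairs.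

The compounds shown leave open whether the step would hold for other groups in the same place, such as a nitrile, an amine or a carboxylic acid, and whether it would hold with a longer chain linking the sulfur to the aromatic ring. Among these compounds, they also leave open how far the core and the place of the group each count, as no pair varies either one alone.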